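Amide nitrogen substituents: from compound 3 to compound 4

This account rests on a few compounds, and the source may have more. Where it says the series, first, only, none or still open, it means among the compounds named here.

Measured values (an ADME assay on L02 cells (Homo sapiens) for antiproliferative activity, read by MTT assay, with a stated time of 48 h; a higher number here means a weaker inhibitor, a lower number a stronger inhibitor)
- compound 1 `CCn1c(C(=O)NCCCN(C)C)ccc1C(CC)(CC)c1ccc(OCCC(O)(CC)CC)c(C)c1` (2420 nM)
- compound 2 `C#CCCOC(=O)c1ccc(C(CC)(CC)c2ccc(OCCC(O)(CC)CC)c(C)c2)n1CC` (> 50000 nM, a limit of the assay)
- compound 3 `CCn1c(C(=O)NC(C)C(=O)O)ccc1C(CC)(CC)c1ccc(OCCC(O)(CC)CC)c(C)c1` (4040 nM)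

Compound 3 stands within the scatter of compound 1 (a 1.7-fold higher number from compound 1 to compound 3 (0.22 log units; within the scatter)). The other two steps are large (an at least 20-fold higher number from compound 1 to compound 2 (1.31 log units; beyond the scatter); an at least 12-fold lower number from compound 2 to compound 3 (1.09 log units; beyond the scatter)). Both concern (but-3-yn-1-yl)oxy on the carbonyl carbon, which compound 4 `CCn1c(C(=O)NC(CO)CCO)ccc1C(CC)(CC)c1ccc(OCCC(O)(CC)CC)c(C)c1` does not carry. Compound 4 keeps the amide-type nitrogen and has 3-hydroxy-1-(hydroxymethyl)propyl in place of 1-carboxyethyl (3-hydroxy-1-(hydroxymethyl)propyl in place of 1-carboxyethyl on an amide-type nitrogen). Going by the values given here, the closest precedent is therefore the exchange on that nitrogen between compound 1 and compound 3 (a 1.7-fold higher number from compound 1 to compound 3 (0.22 log units; within the scatter)), a single step that stayed within the scatter. On that basis, no change beyond the scatter is expected in this assay, and the expected step is small (a 1.1-fold higher number from compound 3 to compound 4 (0.05 log units; within the scatter)). For compound 4 the estimated value is 4500 nM (expected range 1500 nM to 15000 nM).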

Compound 4, half-maximal inhibitory concentration: 3040 nM
Compound 4: the middle estimate sits 1.5-fold (0.17 log units) above what was measured; measured number inside the range.
By their numbers in this assay, from the lowest: compounds 1, 4 and 3 (each within the scatter of the next). At a limit, above all of these: compound 2.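

With 3-hydroxy-1-(hydroxymethyl)propyl on the amide-type nitrogen, this assay shows no step beyond the scatter against either earlier amide: a 1.3-fold lower number from compound 3 to compound 4 (0.12 log units; within the scatter), and a 1.3-fold higher number from compound 1 to compound 4 (0.10 log units; within the scatter). This position has now carried 3-(dimethylamino)propyl, 1-carboxyethyl and 3-hydroxy-1-(hydroxymethyl)propyl, and these three amides, compounds 1, 3 and 4, are not separated by this read-out. The large gap remains on the carbonyl carbon, an at least 16-fold lower number from compound 2 to compound 4 (1.21 log units; beyond the scatter), and the value of compound 2 behind that step is a limit of the assay, not a number: the limit of > 50000 nM in this assay, at which 1 of the 4 values shown sits.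

Going by these compounds, how an unbranched alkyl chain or a morpholine ring on the amide-type nitrogen would compare with these three amides remains open. Also open, on these data alone, is whether a plain ethoxy group on the carbonyl carbon would match (but-3-yn-1-yl)oxy in compound 2.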